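The source may report more compounds than this note shows. Statements on the series, on what has been measured and on what is new or still open speak of the compounds shown alone.

Measured so far:
compound 1, `CC(C)C[C@H](N)c1ccccc1N1CCN(C(=O)[C@H](C)Cc2ccc(Cl)cc2F)CC1`: 67 nM
compound 2, `CC(C)C[C@H](N)c1cc(C(F)(F)F)ccc1N1CCN(C(=O)[C@H](C)Cc2ccc(Cl)cc2)CC1`: 31 nM
compound 3, `CC(C)C[C@H](N)c1cc(F)ccc1N1CCN(C(=O)C(C)Cc2ccc(Cl)cc2)CC1`: 390 nM

Each number is an inhibition constant from an assay on HEK293 cells for displacement of a labelled ligand from Melanocortin receptor 4 (Homo sapiens); a lower number here means a stronger inhibitor, a higher number a weaker inhibitor. Among the three, compound 2 gives the lowest number, with compound 1 nearest and compound 3 furthest off; both gaps are beyond the scatter, so compound 2 is the strongest inhibitor of the three. Compound 4, `CC(C)C[C@H](N)c1cc(C(F)(F)F)ccc1N1CCN(C(=O)COc2ccc(O)cc2)CC1`, is not yet measured. It differs from compound 2 in one place: (4-hydroxyphenoxy)methyl in place of 1-(4-chlorobenzyl)ethyl on a carbonyl carbon. For the measured compounds named here, no measured pair covers a change of this kind; the acyl group that leaves is shared by all three measured compounds, so there is no precedent for its removal. A large step toward a higher number is expected, a 19-fold higher number from compound 2 to compound 4 (1.29 log units; beyond the scatter). Compound 4 is therefore estimated at 600 nM, within 120 nM to 3000 nM.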

Compound 4, inhibition constant: 4600 nM
Beside the measured number, compound 4's estimate is 7.7-fold (0.88 log units) below it; the whole stated range lies below it.
By their numbers in this assay, from the lowest: compound 2; then compound 1; then compound 3; then compound 4.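

In this assay the group on the carbonyl carbon strongly sets the number: (4-hydroxyphenoxy)methyl in place of 1-(4-chlorobenzyl)ethyl gives a 150-fold higher number from compound 2 to compound 4 (2.17 log units; beyond the scatter) and is the only change at this place among the compounds shown. Both groups hold one six-membered aromatic ring of carbon only, so that ring alone does not keep the number low. Nothing measured here explains the loss.

For the compounds shown here, the single step swaps the chlorine, the hydroxyl, the ether oxygen and the methyl branch together, so their shares cannot be separated. From the compounds shown here alone, whether (4-chlorophenoxy)methyl would restore the number remains open.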